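The compounds below may be only part of what the source reports. "The series", "measured", "known", "first", "only" and "open" are said of these compounds alone.

Measured compounds in a functional assay on CHO.K1 cells for antagonist activity at prostaglandin D2 receptor 2 (Homo sapiens), read by GTPgammaS binding, with a stated time of 1 h; a lower number here means a stronger inhibitor, a higher number a weaker inhibitor:
compound 1, `Cc1c(Cc2ccccc2S(=O)(=O)c2cccc(Cl)c2)c2c(n1CC(=O)O)CCNC2=O`, gives 4 nM
compound 2, `Cc1c(Cc2ccc(S(=O)(=O)Cc3ccccc3)cc2)c2c(n1CC(=O)O)CCNC2=O`, gives 3 nM

Compound 1 has the higher of the two numbers, but its gap to compound 2 lies within the usual scatter of repeated measurements, so the two compounds read as equally strong inhibitors in this assay. Compound 3, `Cc1c(Cc2ccccc2C(O)c2ccccc2)c2c(n1CC(=O)O)CCNC2=O`, has not yet been measured. It differs from compound 1 in one place: hydroxy(phenyl)methyl in place of (3-chlorophenyl)sulfonyl on an aromatic carbon. Going by the values given here, no pair of measured compounds covers a change of this kind, so the size of the step can only be expected, not read off. Both measured compounds contain a sulfonyl and both sit at the strong end of this assay, while compound 3 carries none. A moderate weakening is expected, a step of a 6.3-fold higher number from compound 1 to compound 3 (0.80 log units; beyond the scatter) beyond the scatter. Compound 3 is therefore estimated at 25 nM in this assay, with a likely range from 5 nM to 150 nM.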

Compound 3, half-maximal inhibitory concentration in the prostaglandin D2 receptor 2 assay: 32 nM
The estimate for compound 3 lay 1.3-fold (0.11 log units) below the measured number, within the range that was stated.
By their numbers in the prostaglandin D2 receptor 2 assay, from the lowest: compounds 2 and 1 (each within the scatter of the next); then compound 3.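

In the prostaglandin D2 receptor 2 assay compound 1 gives 4 nM and compound 3 gives 32 nM: putting hydroxy(phenyl)methyl in place of (3-chlorophenyl)sulfonyl on this aromatic carbon, ortho to a large group, gives an 8.0-fold higher number from compound 1 to compound 3 (0.90 log units; beyond the scatter), the first sign that inhibition responds to what sits at this position. In a physicochemical assay for acid dissociation, using potentiometric titration, compound 1 gives 3.1 and compound 3 gives 3.1; the same change gives no change at the digits printed from compound 1 to compound 3 (within the scatter), so this read-out does not separate the pair, while the inhibition read-out does. Nothing measured here accounts for the weakening.

The change removes the sulfonyl and the chlorine at once, and the compounds shown do not tell which of the two, if either, carries the step. Also open, from the compounds shown here alone, is how a carbonyl or an amine joining the two aromatic rings would read in the prostaglandin D2 receptor 2 assay, and whether either would bring the number back towards that of compound 1.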